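Hydroxyphenyl placement on the shared pyridine-free core

The source may report more compounds than this note shows. Statements on the series, on what has been measured and on what is new or still open speak of the compounds shown alone.

Among the measured compounds shown here, compound 1 `Oc1cccc(-c2cc(-c3cccs3)cc(-c3ccccc3O)n2)c1` and compound 2 `Oc1ccccc1-c1cc(-c2cccnc2)cc(-c2ccccc2O)n1` are the two measured members of this set, both tested in a functional assay on HCT-15 cells (Homo sapiens) for cytotoxicity, read by CCK-8 assay (a lower number here means a stronger inhibitor, a higher number a weaker inhibitor), for their half-maximal inhibitory concentration. Compound 1 is reported only as a limit of the assay, > 50000 nM, not as a number. Compound 2 likewise reaches only a limit, > 50000 nM, so no number is known for it. Compound 2 therefore stands at the limit described by the limit of > 50000 nM in this assay, at which 2 of the 2 values shown sit, with nothing in the set placed below it.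

Compound 3 `Oc1cccc(-c2cc(-c3cccnc3)cc(-c3ccccc3O)n2)c1` is the unmeasured member. It differs from compound 2 by 3-hydroxyphenyl in place of 2-hydroxyphenyl on an aromatic carbon. For the measured compounds named here, no measured pair in the set shows the size of such a step, and the two values available are both limits, so no direction can be read from them. The expectation for compound 3 is that the assay again returns a limit, with the step that the limit leaves unreadable from compound 2 to compound 3 estimated as none beyond the scatter. Compound 3 is estimated at 60000 nM in this assay, within a range from 20000 nM to 200000 nM.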

Compound 3, half-maximal inhibitory concentration: 8280 nM
The estimate for compound 3 lay 7.2-fold (0.86 log units) above the measured number; the measured number lies below the stated range.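

In this assay, among the compounds shown here, compound 3 is the only member of the set to return a number rather than a limit, and 3-hydroxyphenyl in place of 2-hydroxyphenyl next to the ring nitrogen gives an at least 6.0-fold lower number from compound 2 to compound 3 (0.78 log units; beyond the scatter). With 3-hydroxyphenyl held, pyridin-3-yl in place of thiophen-2-yl gives an at least 6.0-fold lower number from compound 1 to compound 3 (0.78 log units; beyond the scatter), so within this set a measurable number appears only where the two groups occur together. Both steps give only a minimum size, because compound 1 and compound 2 each stand at a limit of the assay rather than at a number: the limit of > 50000 nM in this assay, at which 2 of the 3 values shown sit.

Open, as far as these compounds go, is how a methoxyphenyl or aminophenyl group would read in place of 3-hydroxyphenyl at this position. Also open, from the compounds shown here alone, is whether the 2-hydroxyphenyl group shared by all three compounds contributes to the number in compound 3.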